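The source may hold more compounds than are shown below. What is called first, only, known or untested is meant among the compounds shown, and "the series" means these compounds.

Measured so far:
compound 1 `N#CC1=C(N)Oc2c(c3nc4ccccc4nc3c3ccccc23)C12C(=O)N(Cc1cnnn1-c1ccccc1Cl)c1ccccc12` — > 50000 nM
compound 2 `CCOc1ccc(-n2nncc2CN2C(=O)C3(C(C#N)=C(N)Oc4c3c3nc5ccccc5nc3c3ccccc43)c3ccccc32)cc1` — > 50000 nM

In an ADME assay on L02 cells (Homo sapiens) for antiproliferative activity, read by MTT assay, with a stated time of 48 h (on this read-out higher numbers stand for weaker inhibition and lower numbers for stronger inhibition), compound 1 gives > 50000 nM, which is a limit of the assay and not a number. In this assay compound 2 likewise gives > 50000 nM, again a limit. Among the measured compounds shown here, compound 2 therefore stands at the limit, and the one other value shown sits there too. The step that the two limits leave unreadable from compound 1 to compound 2 stays unreadable because both values rest at the limit of > 50000 nM in this assay, at which 2 of the 2 values shown sit.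

Compound 3 `N#CC1=C(N)Oc2c(c3nc4ccccc4nc3c3ccccc23)C12C(=O)N(Cc1cnnn1-c1ccc(N)cc1)c1ccccc12` differs from compound 2 by amino in place of ethoxy on an aromatic carbon. For the measured compounds named here, the only measured step that bears on this part of the molecule is a step that the two limits leave unreadable from compound 1 to compound 2, whose size is not readable, so the data give no direction for the change. Compound 3 is expected to remain at the limit, the step of a number no higher from compound 2 to compound 3 (the limit leaves the size open) being an estimate of no change beyond the scatter. For compound 3 the estimate in this assay is 50000 nM, with a range from 15000 nM to 150000 nM.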

Compound 3, half-maximal inhibitory concentration: > 50000 nM
Compound 3 ended at the assay's limit (the forecaster's own chance of this, stated with the estimate: 80%); the middle value sits exactly at the limit.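

No step can be read among compound 1, compound 2 and compound 3, since all three values are limits of the assay and not numbers: the limit of > 50000 nM in this assay, at which 3 of the 3 values shown sit.

In this assay the compounds shown leave open whether 2-chlorophenyl, 4-ethoxyphenyl and 4-aminophenyl differ at all.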